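Amine nitrogen substituent exchange on the shared core of compound 1

The compounds below may be only part of what the source reports. "The series", "measured", "known", "first", "only" and "open" are said of these compounds alone.

Compound 1 `Nc1ccccc1NC(=O)c1ccc(CSC(=S)N2CCN(c3cccnc3)CC2)cc1` is the reference point of this note. Among the compounds with values here, in a functional assay on HeLa cells (Homo sapiens) for antiproliferative activity, read by CCK-8 assay, with a stated time of 72 h, tested at 8 uM (a lower number here means a weaker effect, a higher number a stronger effect of the compound at the concentration tested), compound 1 gives 72.5%, the smallest of the three numbers measured so far, though its gap to each of the other two lies within the scatter. Compound 2 `CCN(Cc1ccncc1)C(=S)SCc1ccc(C(=O)Nc2ccccc2N)cc1` gives 77.7% and compound 3 `Nc1ccccc1NC(=O)c1ccc(CSC(=S)N2CCCC2)cc1` gives 77.8%. Within the data shown here, the only single-place step among the measured compounds, a number 0.1 percentage points higher from compound 2 to compound 3 (within the scatter), concerns the group on the thiocarbonyl carbon and is within the scatter; three different amine groups at that position leave the read-out at about the same level.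

Compound 4 `Nc1ccccc1NC(=O)c1ccc(CSC(=S)N2CCN(Cc3ccccc3)CC2)cc1` differs from compound 1 as follows: benzyl in place of pyridin-3-yl on an amine nitrogen in a ring. Among the measured compounds shown here, no measured pair changes this position, so no step bears on it directly. For the measured compounds named here, the one step available, from compound 2 to compound 3, shows that exchanging the amine part elsewhere in the same region left the number unchanged within scatter. On that basis, for compound 4 no step beyond the scatter is expected, which is a number 2.5 percentage points higher from compound 1 to compound 4 (within the scatter). The estimate for compound 4 is 75%, with a range from 62% to 86%.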

Compound 4, a percentage reported as inhibition, at one concentration (the size of the read-out at that concentration, not a potency): 31.3%
Estimate against measurement, compound 4: 43.7 percentage points above, and the stated range ends above it.
By their numbers in this assay, from the lowest: compound 4; then compounds 1, 2 and 3 (each within the scatter of the next).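

In this assay, the group on the amine nitrogen in the ring is not freely exchangeable: a number 41.2 percentage points lower from compound 1 to compound 4 (beyond the scatter), with benzyl in place of pyridin-3-yl. Within the data shown here, the only earlier step, a number 0.1 percentage points higher from compound 2 to compound 3 (within the scatter), concerned the whole amine group on the thiocarbonyl carbon, so its flat result does not carry over to this position. No available evidence accounts for this drop.

The exchange removes the ring nitrogen and also adds a methylene link between the aromatic ring and the amine nitrogen, and the compounds shown do not separate these two changes. Phenyl or pyridin-3-ylmethyl on the same nitrogen would tell them apart, and whether the loss extends to other groups at this position remains open.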